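Aryl urea series: dropping one chloro from compound 1

The source may report more compounds than this note shows. Statements on the series, on what has been measured and on what is new or still open speak of the compounds shown alone.

Three aryl ureas on the shared core have been measured in a functional assay on T-24 cells (Homo sapiens) for antiproliferative activity, read by MTT assay, with a stated time of 48 h; on this read-out higher numbers stand for weaker inhibition and lower numbers for stronger inhibition. Compound 1 `O=C(Nc1cccc(CNc2nccnc2Cl)c1)Nc1ccc(Cl)cc1Cl` gives 5740 nM in this assay, the lowest of the three numbers, though not separated from compound 2. Compound 2 `CC(C)(C)c1ccc(NC(=O)Nc2cccc(CNc3nccnc3Cl)c2)cc1` gives 6010 nM, which lies within the scatter of compound 1, so no order can be read between these two. Within the data shown here, compound 3 `CS(=O)(=O)c1ccc(NC(=O)Nc2cccc(CNc3nccnc3Cl)c2)cc1` gives 29300 nM, the only number beyond the scatter of compound 1. Among the measured compounds shown here, the one step between measured compounds that differ in a single place is a 4.9-fold higher number from compound 2 to compound 3 (0.69 log units; beyond the scatter), methylsulfonyl in place of tert-butyl on an aromatic carbon.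

Compound 4 `O=C(Nc1cccc(CNc2nccnc2Cl)c1)Nc1ccccc1Cl` has not yet been measured. It differs from compound 1 by hydrogen in place of chloro on an aromatic carbon. For the measured compounds named here, no measured step removes or moves a chloro group, and the step between compound 2 and compound 3 concerns a different group at a different place, so nothing bears directly on this change. With no guide available, the expectation for compound 4 is a step of a 1.4-fold higher number from compound 1 to compound 4 (0.14 log units; within the scatter), staying inside the usual scatter. Compound 4 is therefore estimated at 8000 nM in this assay, with a range from 3000 nM to 20000 nM.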

Compound 4, half-maximal inhibitory concentration: 6680 nM
The estimate for compound 4 lay 1.2-fold (0.08 log units) above the measured number; the measured number falls inside the stated range.
By their numbers in this assay, from the lowest: compounds 1, 2 and 4 (each within the scatter of the next); then compound 3.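

In this assay, going from 2,4-dichlorophenyl to 2-chlorophenyl, with hydrogen in place of chloro on an aromatic carbon para to a large group and meta to a chloro group, gives a 1.2-fold higher number from compound 1 to compound 4 (0.07 log units; within the scatter), so the two compounds cannot be told apart on this read-out. Among these compounds, until now the only single-place step concerned tert-butyl and methylsulfonyl; this is the first to touch a chloro group, and it shows that the series tolerates the loss of this one chloro without a readable difference. No measurement shown gives a reason for this result.

The compounds shown leave open what a methoxy group, an amine or a carboxylic acid would give on this same aromatic carbon, as the single-place comparison here covers only chloro and hydrogen. Also open is the part played by the remaining chloro group in compound 4 , which gives 6680 nM, since no step shown removes or moves that group.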